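This account rests on a few compounds, and the source may have more. Where it says the series, first, only, none or still open, it means among the compounds named here.

Compound 1 `CCOC(=O)c1c(-c2ccccc2)[nH]c2cc(OC)ccc2c1=O`, compound 2 `CCOC(=O)c1c(-c2cccc(F)c2)[nH]c2cccc(OC)c2c1=O` and compound 3 `CCOC(=O)c1c(-c2cccc(OC)c2)[nH]c2cc(OC)ccc2c1=O` share a core and have all been tested in a physicochemical assay for solubility, in phosphate buffer, at pH 7.4; a lower number here means a less soluble compound, a higher number a more soluble compound. Compound 1 reads > 100000 nM, which is a limit of the assay and not a number. Compound 2 reads > 100000 nM, also a limit. Compound 3 reads > 100000 nM, again a limit. Compound 2 therefore has no exact value and stands with the other two: the limit of > 100000 nM in this assay, at which 3 of the 3 values shown sit.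

Compound 4 `CCOC(=O)c1c(-c2ccccc2Cl)[nH]c2cccc(OC)c2c1=O` is still unmeasured. It carries 2-chlorophenyl in place of 3-fluorophenyl on an aromatic carbon, next to the ring nitrogen (2-chlorophenyl in place of 3-fluorophenyl on an aromatic carbon). Among the measured compounds shown here, the one measured step, a step that the two limits leave unreadable from compound 1 to compound 3, concerns a different change and gives no size to carry over. For the measured compounds named here, no measured step bears directly on this exchange, so no change beyond the usual scatter is expected in this assay, and no direction can be named. The expected step is a number no higher from compound 2 to compound 4 (the limit leaves the size open). For compound 4 the estimate is 100000 nM, with an expected range from 30000 nM to 200000 nM, and the reading may again be only a limit.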

Compound 4, solubility: > 100000 nM
Compound 4 was reported as a limit; the forecaster's own chance of this, stated with the estimate: 70%; the middle value lies on the limit itself.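

No new step can be read between compound 2 and compound 4, because both readings in this assay are limits and not numbers: the limit of > 100000 nM in this assay, at which 4 of the 4 values shown sit.

The compounds shown leave open whether 2-chlorophenyl in place of 3-fluorophenyl changes the true solubility at all, and how the four compounds rank in this assay.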